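One Carbon Longer: Expected Cytotoxicity of Compound 4

A few compounds are considered here, and "the series" means these few. Any claim that something is new, unique, unknown or untested is made for them only; others in the source may bear on it.

Compound 1 `CCCCCCCCCc1cc2cn(COCCO)c(=O)nc2o1` was tested in a functional assay on HEL cells (Homo sapiens), read by microscopy (on this read-out higher numbers stand for lower toxicity in this test and lower numbers for higher toxicity in this test), and gave >= 16000 nM, a value that is a limit of the assay rather than a number. Compound 2 `CCCCCCCCC#Cc1cc2cn(COCCO)c(=O)nc2o1` also reached only a limit in this assay, namely >= 20000 nM. Compound 3 `C#Cc1cn(COCCO)c(=O)[nH]c1=O` likewise gave a limit in this assay, > 400000 nM. For the measured compounds named here, compound 1 stands at one of these limits, and since all three values shown are limits, no ordering among the compounds can be drawn from them. Compound 4 `CCCCCCCCCCc1cc2cn(COCCO)c(=O)nc2o1` differs from compound 1 by methyl in place of hydrogen on a saturated chain carbon, nine bonds along the chain from an aromatic carbon. Going by the values given here, with no measured step to lean on, the step of a number no higher from compound 1 to compound 4 (the limit leaves the size open) is expected to stay within the scatter. Compound 4 is estimated at 16000 nM, in a range from 8000 nM to 40000 nM, and is expected to be reported again as a limit.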

Compound 4, minimum cytotoxic concentration: 400000 nM
Compound 4: the middle estimate sits 25-fold (1.40 log units) below what was measured; the whole stated range lies below it.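

No step from compound 1 to compound 4 can be read, because compound 1 stands only at a limit: the limit of >= 16000 nM in this assay, at which 1 of the 4 values shown sits.

The compounds shown leave open whether methyl in place of hydrogen at this chain end changes the read-out of this assay at all, and by how much.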